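Notes on the triazolyl series: bromo to amino swap

A few compounds are considered here, and "the series" means these few. Any claim that something is new, unique, unknown or untested is made for them only; others in the source may bear on it.

Two compounds of the series have numbers in a functional assay on MCF7 cells (Homo sapiens) for antiproliferative activity, read by MTT assay, with a stated time of 48 h (on this read-out lower numbers stand for stronger inhibition and higher numbers for weaker inhibition), so far. Compound 1 `N#CC1=C(N)Oc2c(c3nc4ccccc4nc3c3ccccc23)C12C(=O)N(Cc1cnnn1-c1cccc(Cl)c1)c1ccccc12` gives 43600 nM in this assay. Compound 2 `N#CC1=C(N)Oc2c(c3nc4ccccc4nc3c3ccccc23)C12C(=O)N(Cc1cnnn1-c1ccc(Br)cc1)c1ccccc12` gives 36600 nM in this assay. Within the data shown here, the single measured step, a 1.2-fold lower number from compound 1 to compound 2 (0.08 log units; within the scatter), is within the scatter, so compound 2 holds the lower of the two numbers without standing apart from compound 1.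

Compound 3 `N#CC1=C(N)Oc2c(c3nc4ccccc4nc3c3ccccc23)C12C(=O)N(Cc1cnnn1-c1ccc(N)cc1)c1ccccc12` is not yet measured. It differs from compound 2 by amino in place of bromo on an aromatic carbon. Among the measured compounds shown here, the only measured step that bears on it is the one from compound 1 to compound 2, which also changes the substituent on the aryl ring of the triazole and produced no movement beyond the scatter; no measured step exchanges a halogen for an amino group, so there is no direct precedent for the present change. On this thin basis no step beyond the scatter is expected in this assay for compound 3, and the expected step is a 1.0-fold lower number from compound 2 to compound 3 (0.01 log units; within the scatter). Compound 3 is therefore estimated at 36000 nM in this assay, with a range from 12000 nM to 110000 nM.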

Compound 3, half-maximal inhibitory concentration: > 50000 nM
Compound 3 gave a limit, no number; the forecaster's own chance of this, stated with the estimate: 10%; middle value at least 1.3-fold (0.14 log units) away from the limit.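

Compound 3 gives only a limit in this assay, not a number: the limit of > 50000 nM in this assay, at which 1 of the 3 values shown sits. Read as floors, amino in place of bromo, on an aromatic carbon para to a large group, gives an at least 1.3-fold higher number from compound 2 to compound 3 (0.13 log units; that floor lies within the scatter) and the exchange of the whole aryl group gives an at least 1.1-fold higher number from compound 1 to compound 3 (0.05 log units; that floor lies within the scatter) and neither floor by itself shows a change beyond the scatter. What is new is that a group other than a halogen has been tested on this aryl ring, with a hydrogen-bond donor entering where the bromo had none, and it brings no lower number, while the true size of the step stays unread.

Open, as far as these compounds go, is whether a methoxy group, a carboxylic acid or an acetamide at the same place would move the number in this assay beyond the scatter. Also open, from the compounds shown here alone, is whether a plain phenyl group would read differently from the substituted rings, and so whether any substituent on this ring matters at all next to the shared core.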